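The source may hold more compounds than are shown below. What is called first, only, known or untested is meant among the compounds shown, and "the series" means these compounds.

In a functional assay on A549 cells (Homo sapiens) for antiproliferative activity, read by MTT assay, with a stated time of 72 h (on this read-out higher numbers stand for weaker inhibition and lower numbers for stronger inhibition), compound 3 `O=C(CCCCCCc1nc(-c2ccccc2)no1)C(F)(F)F` gives 7680 nM. This lies within the scatter of compound 1 `O=C(CCCCCCc1nc(-c2cccc([N+](=O)[O-])c2)no1)NO`, which gives 10800 nM, and clearly under compound 2 `Nc1ccccc1NC(=O)CCCCCCc1nc(-c2cccc([N+](=O)[O-])c2)no1`, which gives 20200 nM.

Compound 4 `O=C(CCCCCCc1nc(-c2cccc([N+](=O)[O-])c2)no1)C(F)(F)F` keeps the trifluoromethyl group of compound 3 and has one change: nitro in place of hydrogen on an aromatic carbon. Among the measured compounds shown here, no measured pair isolates this change. For the measured compounds named here, the only measured step, with 2-aminophenyl in place of hydroxy on an amide-type nitrogen, is a 1.9-fold higher number from compound 1 to compound 2 (0.27 log units; within the scatter). It concerns the other end of the molecule, and both of its compounds already carry nitro, so it offers only indirect guidance. Still, compound 1 carries nitro and its value of 10800 nM sits within the scatter of compound 3, so nitro does not appear to rule out a similar number. The expected step is a 1.1-fold higher number from compound 3 to compound 4 (0.04 log units; within the scatter), with no shift beyond the scatter anticipated. Compound 4 is estimated at 8500 nM, with an expected range from 3500 nM to 20000 nM.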

Compound 4, half-maximal inhibitory concentration: 9580 nM
Compound 4: the middle estimate sits 1.1-fold (0.05 log units) below what was measured, and the stated range covers the measured number.
By their numbers in this assay, from the lowest: compounds 3, 4, 1 and 2 (each within the scatter of the next, the first and the last beyond it).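

In this assay, among the compounds shown here, placing nitro on the aromatic carbon, meta to a large group, gives a 1.2-fold higher number from compound 3 to compound 4 (0.10 log units; within the scatter) and so offers the first direct reading of this change: on the compounds with a trifluoromethyl group, nitro at this position leaves the number within the scatter. Compound 4 also allows the carbonyl end to be compared with nitro present on every compound: trifluoromethyl in place of hydroxyamino gives a 1.1-fold lower number from compound 1 to compound 4 (0.05 log units; within the scatter) while trifluoromethyl in place of (2-aminophenyl)amino gives a 2.1-fold lower number from compound 2 to compound 4 (0.32 log units; beyond the scatter) and only this last, modest step lies beyond the scatter. Nothing available here explains why the numbers fall this way.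

Going by these compounds, whether nitro behaves the same way elsewhere on the aromatic ring remains open. So does whether another group at this position, such as an amine or a carboxylic acid, would shift the number beyond the scatter.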